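This account rests on a few compounds, and the source may have more. Where it says the series, first, only, none or still open, it means among the compounds named here.

Of the compounds shown here, two that share one core have been tested in an assay on DDT1 cells (Cricetulus griseus) for binding affinity to adenosine receptor A1 (Homo sapiens), read by radioligand binding; on this read-out higher numbers stand for weaker inhibition and lower numbers for stronger inhibition. Compound 1 `CC/N=C(\S)OC[C@H]1OC(n2cnc3c(NC4CCOC4)nc(Cl)nc32)[C@H](O)[C@@H]1O` gives 55 nM in this assay. Going by the values given here, compound 2 `CC(C)NC(=O)OC[C@H]1OC(n2cnc3c(NC4CCOC4)ncnc32)[C@H](O)[C@@H]1O` gives 78 nM in this assay; that number and the one for compound 1 sit within the usual scatter of each other, so the two cannot be told apart. Compound 3 `CN(C)C(=O)OC[C@H]1OC(n2cnc3c(NC4CCOC4)ncnc32)[C@H](O)[C@@H]1O` has not yet been measured. It differs from compound 2 in one place: dimethylamino in place of isopropylamino on a carbonyl carbon. Among the compounds with values here, no measured pair shows this change, so there is no yardstick for it; the step is expected to be small and in no sure direction, a 1.2-fold higher number from compound 2 to compound 3 (0.06 log units; within the scatter). Compound 3 is therefore estimated at 90 nM, within 40 nM to 200 nM.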

Compound 3, inhibition constant: 238 nM
Compound 3: the middle estimate sits 2.6-fold (0.42 log units) below what was measured, and the stated range ends below it.
By their numbers in this assay, from the lowest: compounds 1 and 2 (each within the scatter of the next); then compound 3.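

In this assay the change of isopropylamino to dimethylamino on a carbonyl carbon gives a 3.1-fold higher number from compound 2 to compound 3 (0.48 log units; beyond the scatter) and so is not a silent swap. The earlier compounds shown here could not show this, since compound 1 and compound 2 differ in more than one place. The change also takes away the one hydrogen-bond donor of the leaving group, but no measurement here explains the step. From the compounds shown here alone, what stays open is whether the lost amide hydrogen or the altered carbon groups track with the step; methylamino or cyclopropylamino on the same carbonyl carbon would help separate the two.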